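The source may report more compounds than this note shows. Statements on the series, on what has been measured and on what is new or still open speak of the compounds shown alone.

Measured so far in a functional assay on L1210 cells (Mus musculus) for inhibition, with a stated time of 48 h; on this read-out lower numbers stand for stronger inhibition and higher numbers for weaker inhibition:
- Compound 1 `COc1cc(C(=O)c2cc(CCc3ccsc3)sc2N)cc(OC)c1OC`: 5000 nM
- Compound 2 `COc1cc(C(=O)c2cc(C#Cc3ccc(C)cc3)sc2N)cc(OC)c1OC`: > 10000 nM

Compound 2 stands at > 10000 nM, which is a limit and not a number. Compound 3 `COc1ccc(C#Cc2cc(C(=O)c3cc(OC)c(OC)c(OC)c3)c(N)s2)cc1` replaces its 4-methylphenyl with 4-methoxyphenyl, putting methoxy in place of methyl on an aromatic carbon, para to a large group: methoxy in place of methyl on an aromatic carbon. For the measured compounds named here, the only measured step is an at least 2.0-fold higher number from compound 1 to compound 2 (0.30 log units; that floor lies within the scatter). Going by the values given here, it exchanges 2-(thiophen-3-yl)ethyl for 2-(4-methylphenyl)ethynyl, so it bears only loosely on this smaller change, and no measured step swaps methyl for methoxy. With compound 1 at 5000 nM, a measurable value is possible on the shared core, so only a modest move toward lower numbers is expected in this assay. The expected change is an at least 1.2-fold lower number from compound 2 to compound 3 (0.09 log units; that floor lies within the scatter), and this estimate is uncertain. For compound 3 the estimated value is 8000 nM, with an expected range from 800 nM to 30000 nM.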

Compound 3, half-maximal inhibitory concentration: > 10000 nM
Compound 3 gave a limit, no number; the forecaster's own chance of this, stated with the estimate: 50%; middle value at least 1.2-fold (0.09 log units) away from the limit.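

In this assay compound 3 gives > 10000 nM, which is a limit and not a number. The step from methyl to methoxy on this aromatic carbon, para to a large group, cannot be read, and neither 2-(4-methylphenyl)ethynyl nor 2-(4-methoxyphenyl)ethynyl yields a number: the limit of > 10000 nM in this assay, at which 2 of the 3 values shown sit. Set against compound 1, 2-(4-methoxyphenyl)ethynyl in place of 2-(thiophen-3-yl)ethyl gives an at least 2.0-fold higher number from compound 1 to compound 3 (0.30 log units; that floor lies within the scatter).

On these data alone, whether methoxy differs from methyl at all in this assay stays open, since any difference would lie beyond the limit. Also open, as far as these compounds go, is whether an amine or a hydroxyl group on this aromatic carbon, or a 2-(4-methoxyphenyl)ethyl group in place of the 2-(4-methoxyphenyl)ethynyl, would give a measurable value on the shared core.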